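Pentylsulfanyl extension at the sulfur of compound 2

The compounds below may be only part of what the source reports. "The series", "measured", "known", "first", "only" and "open" are said of these compounds alone.

Compound 2 `Nc1nc(S)nc2c1nc(O)n2Cc1ccccc1` is the higher of the two numbers recorded so far in a functional assay (spleen, spleen) for activation, with Mus musculus as the target; on this read-out lower numbers stand for an effect already at smaller amounts and higher numbers for an effect only at larger amounts of compound: compound 2 gives 10 uM. Within the data shown here, its nearest neighbour, compound 1 `CNc1nc(N)c2nc(O)n(Cc3ccccc3)c2n1`, gives 1 uM in this assay, and the single measured step, a 10-fold higher number from compound 1 to compound 2 (1.00 log units; beyond the scatter), was a modest one beyond the scatter.

Compound 3 `CCCCCSc1nc(N)c2nc(O)n(Cc3ccccc3)c2n1` is the next step from compound 2, with pentyl in place of hydrogen on a sulfur. Among the measured compounds shown here, the only measured step exchanges the substituent on the aromatic carbon itself and does not touch the sulfur, so nothing recorded so far speaks to the effect of extending the sulfanyl to pentylsulfanyl. For the measured compounds named here, with no step to rest on, no change beyond the scatter is expected in this assay, and the estimate for compound 3 is set close to compound 2 with a wide range: compound 3 is expected to give 10 uM (2 uM to 50 uM), that is an estimated step of no change at the digits printed from compound 2 to compound 3 (within the scatter).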

Compound 3, minimum effective concentration: 10 uM
For compound 3 middle estimate and measured number coincide at the digits printed; low and high end bracket the measured number.
By their numbers in this assay, from the lowest: compound 1; then compounds 2 and 3 (each within the scatter of the next).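

Among these compounds, on the sulfur, pentyl in place of hydrogen gives no change at the digits printed from compound 2 to compound 3 (within the scatter) in this assay, the first reading at this position, so this substituent is carried there without a shift beyond the scatter. Among the compounds shown here, replacing methylamino on the aromatic carbon with pentylsulfanyl gives a 10-fold higher number from compound 1 to compound 3 (1.00 log units; beyond the scatter), so both sulfur-linked substituents shown sit apart from methylamino, which is the only group here with a number beyond the scatter from the others. No evidence on hand accounts for either result.

As far as these compounds go, whether the sulfur also accepts a shorter chain such as methyl, a longer chain such as decyl, or a pentyl chain ending in an amine or a carboxylic acid remains open. Also open, from the compounds shown here alone, is whether a longer nitrogen-linked chain such as butylamino on the aromatic carbon stays near compound 1 at 1 uM.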